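The compounds below may be only part of what the source reports. "The series", "measured", "known", "first", "only" and "open" are said of these compounds alone.

In a functional assay on HL-60 cells (Homo sapiens) for antiproliferative activity, read by sulforhodamine B assay, with a stated time of 72 h (on this read-out lower numbers stand for stronger inhibition and higher numbers for weaker inhibition), compound 1 `CN(C)C(=S)N/N=C/c1ccc2cccnc2n1` gives 560 nM, compound 2 `N#Cc1ccc(NC(=S)N/N=C/c2ccc3ccccc3n2)cc1` gives 4660 nM, and compound 3 `S=C(NCc1ccccc1)N/N=C/c1ccc2ccccc2n1` gives 21900 nM, the highest of the three numbers and so the weakest inhibition among them. Compound 4 `Cc1ccc(NC(=S)N/N=C/c2ccc3ccccc3n2)cc1` carries 4-methylphenyl in place of benzyl on an amide-type nitrogen whose other neighbour is the thiocarbonyl carbon: 4-methylphenyl in place of benzyl on an amide-type nitrogen. Among the compounds with values here, one measured step bears on this change, a 4.7-fold higher number from compound 2 to compound 3 (0.67 log units; beyond the scatter), with benzyl in place of 4-cyanophenyl on that same nitrogen. Compound 4 keeps a substituted phenyl there as compound 2 does, but with a different group, so this single step is limited support. Reading that step in reverse, a modest fall of similar size is expected in this assay, and the estimated step is a 3.4-fold lower number from compound 3 to compound 4 (0.53 log units; beyond the scatter). For compound 4 the expected value is 6500 nM, with an estimated range of 2000 nM to 20000 nM.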

Compound 4, half-maximal inhibitory concentration: 78300 nM
Compound 4: middle estimate off by 12-fold (1.08 log units), on the low side; the whole stated range lies below it.
By their numbers in this assay, from the lowest: compound 1; then compound 2; then compound 3; then compound 4.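

In this assay the change from benzyl to 4-methylphenyl on the amide-type nitrogen brings a 3.6-fold higher number from compound 3 to compound 4 (0.55 log units; beyond the scatter) and shows that a substituted phenyl on this nitrogen does not in itself give a lower number than benzyl: 4-cyanophenyl does, 4-methylphenyl does not. The group on the aromatic carbon makes the larger difference, as methyl in place of cyano gives a 17-fold higher number from compound 2 to compound 4 (1.23 log units; beyond the scatter) and this large step leaves benzyl with a number between those of the two substituted phenyls. Nothing measured here accounts for these differences.

The compounds shown leave open how a methoxy group, an amine or a carboxylic acid on that aromatic carbon would read. They also leave open whether the same order of these three nitrogen groups would hold on the core of compound 1.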